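Isopropyl in Place of Methoxy: What Compound 4 May Show

A few compounds are considered here, and "the series" means these few. Any claim that something is new, unique, unknown or untested is made for them only; others in the source may bear on it.

Of the compounds shown here, three sharing one core have been measured in an in vivo ADME assay on the whole organism for pharmacokinetics, with Rattus norvegicus as the target, at a dose of 10 mg/kg by the oral route; on this read-out higher numbers stand for higher exposure at the dose given and lower numbers for lower exposure. Compound 1 `CC1(COc2c(N3CCN(S(=O)(=O)Cc4ccc(N)cc4)CC3)cnn(-c3cccc(Cl)c3)c2=O)CC1` gives 3490 nM, compound 2 `CC1(COc2c(N3CCN(S(=O)(=O)Cc4cccc(N)c4)CC3)cnn(-c3cccc(Cl)c3)c2=O)CC1` gives 2570 nM, and compound 3 `COc1cc(CS(=O)(=O)N2CCN(c3cnn(-c4cccc(Cl)c4)c(=O)c3OCC3(C)CC3)CC2)ccc1N` gives 5750 nM. Among the compounds with values here, compound 3 stands highest of the three numbers in this assay, though the step of a 1.6-fold higher number from compound 1 to compound 3 (0.22 log units; within the scatter) is within the scatter and only the step of a 2.2-fold higher number from compound 2 to compound 3 (0.35 log units; beyond the scatter) lies beyond it.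

Compound 4 `CC(C)c1cc(CS(=O)(=O)N2CCN(c3cnn(-c4cccc(Cl)c4)c(=O)c3OCC3(C)CC3)CC2)ccc1N` differs from compound 3 in one place: isopropyl in place of methoxy on an aromatic carbon. Within the data shown here, no measured step exchanges one substituent at this position for another non-hydrogen group, so the closest comparison is a 1.6-fold higher number from compound 1 to compound 3 (0.22 log units; within the scatter), where adding methoxy at this position changed the number only within the scatter. The step of a 2.2-fold higher number from compound 2 to compound 3 (0.35 log units; beyond the scatter) combines two changes and cannot be separated into parts.

Among the measured compounds shown here, on that basis the account expects the step of a 1.3-fold lower number from compound 3 to compound 4 (0.11 log units; within the scatter) to stay within the scatter in this assay, with no clear direction, since the one change at this position, from compound 1 to compound 3, was a 1.6-fold higher number from compound 1 to compound 3 (0.22 log units; within the scatter). Compound 4 is therefore estimated to give 4500 nM, with a range from 1800 nM to 11000 nM.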

Compound 4, maximal plasma concentration: 1190 nM
Beside the measured number, compound 4's estimate is 3.8-fold (0.58 log units) above it, and the stated range ends above it.
By their numbers in this assay, from the lowest: compound 4; then compounds 2, 1 and 3 (each within the scatter of the next, the first and the last beyond it).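

In this assay, within the data shown here, this place on the aromatic ring, ortho to an amino group, proves sensitive to the group it carries: the step of a 4.8-fold lower number from compound 3 to compound 4 (0.68 log units; beyond the scatter) is the first exchange here to go beyond the scatter, whereas the earlier step of a 1.6-fold higher number from compound 1 to compound 3 (0.22 log units; within the scatter) had stayed within it. Measured against hydrogen at the same place, isopropyl also lowers the number, with the step of a 2.9-fold lower number from compound 1 to compound 4 (0.47 log units; beyond the scatter), so the two substituents part ways: methoxy leaves the number within the scatter of the unsubstituted compound, and isopropyl does not. The step of a 2.2-fold lower number from compound 2 to compound 4 (0.33 log units; beyond the scatter), in which 4-amino-3-isopropylphenyl replaces 3-aminophenyl, completes the picture, and compound 4 now has the lowest number of the four, with its steps to all three others beyond the scatter. Nothing available here bears on what lies behind this drop.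

The compounds shown leave open whether the lower number belongs to isopropyl alone, since ethyl, cyclopropyl or a single fluorine at this place would separate a branched chain from other groups. They also leave open whether exposure over time would follow the same order, as this assay records only a maximal concentration after one oral dose.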